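Series notes: acid-to-ester step at the pyridine substituent

The source may report more compounds than this note shows. Statements on the series, on what has been measured and on what is new or still open speak of the compounds shown alone.

Compound 3 `O=C(O)c1cccc(-c2cnc(C(=O)CCc3ccc(-c4ccc(CN5CCCCC5)cc4)cc3)o2)n1` gives 44 nM in an assay for inhibition of Fatty-acid amide hydrolase 1 (Rattus norvegicus) (a higher number here means a weaker inhibitor, a lower number a stronger inhibitor), second highest of the three numbers. For the measured compounds named here, compound 2 `CN1CCN(Cc2ccc(-c3ccc(CCC(=O)c4ncc(-c5cccc(C(=O)O)n5)o4)cc3)cc2)CC1` gives 1200 nM, and the step of a 27-fold lower number from compound 2 to compound 3 (1.44 log units; beyond the scatter) is the only measured step in the set. Compound 1 `N#Cc1cccc(-c2cnc(C(=O)CCc3ccc(COc4ccccc4)cc3)o2)n1` gives 0.56 nM; it differs from compound 3 in more than one place, so only the two values can be compared. Compound 4 `COC(=O)c1cccc(-c2cnc(C(=O)CCc3ccc(-c4ccc(CN5CCCCC5)cc4)cc3)o2)n1` carries methyl in place of hydrogen on an oxygen next to a carbonyl group. Going by the values given here, no measured step bears on this change; the piperidin-1-yl step concerns another part of the structure. Compound 4 is therefore estimated at 10 nM, with a range of 2 nM to 60 nM. The expected step of a 4.4-fold lower number from compound 3 to compound 4 (0.64 log units; beyond the scatter) is a tentative guess toward a lower number, resting only on compound 1 giving 0.56 nM without a carboxy group.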

Compound 4, inhibition constant: 9 nM
Compound 4: the middle estimate sits 1.1-fold (0.05 log units) above what was measured; the range from low to high includes it.
By their numbers in this assay, from the lowest: compound 1; then compound 4; then compound 3; then compound 2.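

In this assay, for the compounds shown here, carboxy to methoxycarbonyl gives a 4.9-fold lower number from compound 3 to compound 4 (0.69 log units; beyond the scatter), the first measured step at this position, with the piperidin-1-yl end held fixed. A free carboxy group is therefore not required here, and the methyl ester is the stronger inhibitor of this pair. Nothing on hand explains the step. Still open, as far as these compounds go, is how a primary carboxamide or an ethoxycarbonyl group would read at this place. Also open, from the compounds shown here alone, is whether the step holds with 4-methylpiperazin-1-yl in place of piperidin-1-yl.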